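Spiro core series: amide terminus change from compound 3 to 4

The source may hold more compounds than are shown below. What is called first, only, known or untested is meant among the compounds shown, and "the series" means these compounds.

Measured compounds:
- compound 1, `COC(=O)CCNC(=O)CN1CN(c2ccccc2)C2(CCN(C(=O)c3ccc(C(C)(C)C)cc3)CC2)C1=O`: in an assay on HEK293 cells for displacement of a labelled ligand from NPC1-like intracellular cholesterol transporter 1 (Homo sapiens) (on this read-out higher numbers stand for weaker inhibition and lower numbers for stronger inhibition), compound 1 gives "not determined" (no result reported), so no result stands for it
- compound 2, `CC(C)(C)c1ccc(C(=O)N2CCC3(CC2)C(=O)N(CC(=O)N2CCCC(O)C2)CN3c2ccccc2)cc1`: in this assay compound 2 gives 12200 nM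
- compound 3, `CC(C)(C)c1ccc(C(=O)N2CCC3(CC2)C(=O)N(CC(=O)NCNS(C)(=O)=O)CN3c2ccccc2)cc1`: in this assay compound 3 gives 3200 nM

Compound 3 holds the lowest of the two numbers; its nearest neighbour is compound 2, and the step of a 3.8-fold lower number from compound 2 to compound 3 (0.58 log units; beyond the scatter) is beyond the scatter. Compound 1 carries no number and cannot be placed.

Compound 4, `CC(C)(C)c1ccc(C(=O)N2CCC3(CC2)C(=O)N(CC(=O)N2CCCCC2CCO)CN3c2ccccc2)cc1`, differs from compound 3 only at the carbonyl carbon: 2-(2-hydroxyethyl)piperidin-1-yl in place of ((methanesulfonamido)methyl)amino on a carbonyl carbon.

Among the compounds with values here, the one step that bears on this is a 3.8-fold lower number from compound 2 to compound 3 (0.58 log units; beyond the scatter), where 3-hydroxypiperidin-1-yl was replaced by ((methanesulfonamido)methyl)amino. Compound 4 walks back from that terminus to a piperidine bearing a hydroxyethyl chain, a terminus closer in kind to that of compound 2 than to that of compound 3. The expectation is therefore a move in the opposite direction, back toward the number of compound 2, with a size of roughly a 2.8-fold higher number from compound 3 to compound 4 (0.45 log units; beyond the scatter), though the hydroxy group now sits on a side chain rather than on the ring, so the match to compound 2 is imperfect and the range is kept wide.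

Compound 4 is estimated at 9000 nM, with a range from 3500 nM to 25000 nM.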

Compound 4, half-maximal inhibitory concentration: 6100 nM
Compound 4: middle estimate off by 1.5-fold (0.17 log units), on the high side; low and high end bracket the measured number.
By their numbers in this assay, from the lowest: compounds 3, 4 and 2 (each within the scatter of the next, the first and the last beyond it).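

At the carbonyl carbon, 2-(2-hydroxyethyl)piperidin-1-yl in place of ((methanesulfonamido)methyl)amino gives a 1.9-fold higher number from compound 3 to compound 4 (0.28 log units; within the scatter) in this assay, and the same group in place of 3-hydroxypiperidin-1-yl gives a 2.0-fold lower number from compound 2 to compound 4 (0.30 log units; within the scatter) on the same read-out. The new terminus thus lies within the scatter of both earlier termini, even though those two are separated by a 3.8-fold lower number from compound 2 to compound 3 (0.58 log units; beyond the scatter) on their own, so this position now reads as a continuous narrow range rather than as two distinct levels. Moving the hydroxy group from the ring onto a side chain produces no step beyond the scatter in either comparison, and no measurement at hand accounts for any of these numbers.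

Going by these compounds, whether plain piperidin-1-yl without a hydroxy group, or a terminus bearing an amine or a carboxylic acid, would fall outside this range remains open. Compound 1 gives "not determined" (no result reported) for its terminus, which ends in a methyl ester, so its steps to the other compounds cannot be read and the effect of an ester at this position is also unresolved.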